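Swapping the 4-Methylpiperidin-1-yl Group of Compound 1

The source may report more compounds than this note shows. Statements on the series, on what has been measured and on what is new or still open speak of the compounds shown alone.

Compound 1 `CC1CCN(c2nc(C(F)(F)Cl)ccc2CNC(=O)C(C)c2ccc(NS(C)(=O)=O)c(F)c2)CC1` gives the lowest number of the three measured compounds in an assay on CHO cells for antagonist activity at transient receptor potential cation channel subfamily V member 1 (Homo sapiens), read by FLIPR (on this read-out higher numbers stand for weaker inhibition and lower numbers for stronger inhibition), at 0.3 nM. Compound 2 `CC(C(=O)NCc1ccc(C(F)(F)Cl)nc1N1CCCCC1)c1ccc(NS(C)(=O)=O)c(F)c1` gives 1.3 nM, and compound 3 `CC1CC(C)CN(c2nc(C(F)(F)Cl)ccc2CNC(=O)C(C)c2ccc(NS(C)(=O)=O)c(F)c2)C1` gives 1 nM. Both of these sit beyond the scatter from compound 1: a 4.3-fold higher number from compound 1 to compound 2 (0.64 log units; beyond the scatter) and a 3.3-fold higher number from compound 1 to compound 3 (0.52 log units; beyond the scatter), whereas a 1.3-fold lower number from compound 2 to compound 3 (0.11 log units; within the scatter). Compound 4 `CC(C(=O)NCc1ccc(C(F)(F)Cl)nc1OCc1ccccn1)c1ccc(NS(C)(=O)=O)c(F)c1` carries a change at this same place: (pyridin-2-yl)methoxy in place of 4-methylpiperidin-1-yl on an aromatic carbon. For the measured compounds named here, no measured step covers this exchange directly; the two steps from compound 1 only show that altering the 4-methylpiperidin-1-yl group, either by putting hydrogen in place of methyl on a saturated ring carbon or by moving to a 3,5-dimethylpiperidin-1-yl group, raised the number modestly in each case. A more thorough exchange of the whole group for (pyridin-2-yl)methoxy is therefore expected to raise the number at least as much, and the range is set wide to reflect the missing precedent. Compound 4 is estimated at 2 nM, between 0.5 nM and 10 nM, which is expected to correspond to a 6.7-fold higher number from compound 1 to compound 4 (0.82 log units; beyond the scatter).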

Compound 4, inhibition constant: 4.2 nM
Beside the measured number, compound 4's estimate is 2.1-fold (0.32 log units) below it; measured number inside the range.
By their numbers in this assay, from the lowest: compound 1; then compounds 3 and 2 (each within the scatter of the next); then compound 4.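

In this assay, for the compounds shown here, the exchange of a saturated ring for (pyridin-2-yl)methoxy at this position, on an aromatic carbon next to the ring nitrogen, costs more than any change among the piperidine groups: the step is large, at a 14-fold higher number from compound 1 to compound 4 (1.15 log units; beyond the scatter), whereas the earlier steps from compound 1 were modest. The loss also holds against the other two piperidine groups, with a 4.2-fold higher number from compound 3 to compound 4 (0.62 log units; beyond the scatter) and a 3.2-fold higher number from compound 2 to compound 4 (0.51 log units; beyond the scatter), so compound 4 is the weakest of the four. Nothing available on these compounds accounts for this difference.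

The exchange alters the ring and its link together, so the share of the oxygen-linked methylene and that of the pyridine ring remain unseparated. From the compounds shown here alone, how a benzyloxy group or a morpholin-4-yl group would stand at this position also stays open.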